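The compounds below may be only part of what the source reports. "The series", "measured", "known", "first", "only" and "open" are said of these compounds alone.

Measured so far:
compound 1, `c1cc(-c2ccn[nH]2)c2c(c1)C(c1ncc[nH]1)CC2`: 336 nM
compound 2, `Cc1c(OCC2=NCCN2)ccc(Cl)c1NS(C)(=O)=O`: > 10000 nM

In a functional assay on CHO cells for agonist activity at Alpha-1D adrenergic receptor (Homo sapiens), read by FLIPR and calcium flux (on this read-out lower numbers stand for an effect already at smaller amounts and higher numbers for an effect only at larger amounts of compound), compound 1 gives 336 nM. That is the only number shown in this assay, so compound 1 has no measured neighbour against which a step could be weighed. For compound 2 the read-out is a limit of the assay rather than a number, > 10000 nM, as noted in the limit of > 10000 nM in this assay, at which 1 of the 2 values shown sits; compound 2 shares no single point of difference with compound 1, so nothing can be drawn from the pair beyond what the two values show.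

Compound 3 `c1cc(-c2ncco2)c2c(c1)C(c1ncc[nH]1)CC2` is the next step from compound 1: 1,3-oxazol-2-yl in place of 1H-pyrazol-5-yl on an aromatic carbon. Within the data shown here, no measured step of this kind exists in the set, so the expectation rests on the change alone. The step of a 3.0-fold higher number from compound 1 to compound 3 (0.47 log units; beyond the scatter) is expected to run toward larger amounts of compound, somewhat beyond the usual scatter. For compound 3 the estimate in this assay is 1000 nM, with a range from 300 nM to 4000 nM.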

Compound 3, half-maximal effective concentration: 1390 nM
For compound 3 the middle estimate is 1.4-fold (0.14 log units) below the measured one, within the range that was stated.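

In this assay, among these compounds, the exchange of 1H-pyrazol-5-yl for 1,3-oxazol-2-yl on this aromatic carbon gives a 4.1-fold higher number from compound 1 to compound 3 (0.62 log units; beyond the scatter) as the first measured step. The position therefore distinguishes between these two five-membered aromatic rings, even though both groups have 5 heavy atoms and no net charge; the entering group has 0 hydrogen-bond donors and 2 hydrogen-bond acceptors, the leaving group 1 of each. No measured evidence ties the step to any one of these differences.

A single pair leaves open whether the step follows the hydrogen-bond count or some other difference between the two rings. Going by these compounds, how a primary amine, a carboxylic acid or a longer alkyl chain would read on this aromatic carbon also remains open.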